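Replacing the dimethylamino group of compound 2

The compounds below may be only part of what the source reports. "The series", "measured", "known", "first", "only" and "open" are said of these compounds alone.

In an in vivo functional assay on the whole organism for inhibition, with Rattus norvegicus as the target (on this read-out lower numbers stand for an effect already at smaller amounts and higher numbers for an effect only at larger amounts of compound), compound 2 `CCCCc1nc(C)c(CC(=O)N(C)C)c(=O)n1Cc1ccc(-c2ccccc2-c2nnn[nH]2)cc1` stands lowest at 0.018 mg/kg and compound 1 `CCCCc1nc(C)c(CCC(=O)OCC)c(=O)n1Cc1ccc(-c2ccccc2-c2nnn[nH]2)cc1` follows at 0.066 mg/kg in the series. Compound 3 `CCCCc1nc(C)c(CC(=O)N2CCN(C)CC2)c(=O)n1Cc1ccc(-c2ccccc2-c2nnn[nH]2)cc1` is recorded as "not determined" (no result reported) with no reported number, so it offers no comparison. The still unmeasured compound 4 `CCCCc1nc(C)c(CC(=O)N2CC(C)OC(C)C2)c(=O)n1Cc1ccc(-c2ccccc2-c2nnn[nH]2)cc1` carries 2,6-dimethylmorpholin-4-yl in place of dimethylamino on a carbonyl carbon, and the difference counts as 2,6-dimethylmorpholin-4-yl in place of dimethylamino on a carbonyl carbon in full. Nothing has been measured for this exact change. Among the measured compounds shown here, the single measured step, a 3.7-fold lower number from compound 1 to compound 2 (0.56 log units; beyond the scatter) as a modest move, replaces a different group and is only a loose guide. A step of that size or smaller, toward a higher number, is expected. The estimated move is a 1.7-fold higher number from compound 2 to compound 4 (0.22 log units; within the scatter) for now. The estimate for compound 4 is 0.03 mg/kg with an expected range of 0.008 mg/kg to 0.12 mg/kg on this scale.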

Compound 4, dose for half-maximal effect: 0.029 mg/kg
The estimate for compound 4 lay 1.0-fold (0.01 log units) above the measured number, and the stated range covers the measured number.
By their numbers in this assay, from the lowest: compounds 2 and 4 (each within the scatter of the next); then compound 1.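

At the carbonyl carbon, 2,6-dimethylmorpholin-4-yl with its six-membered ring is accommodated in place of dimethylamino in this assay (a 1.6-fold higher number from compound 2 to compound 4 (0.21 log units; within the scatter)). The gain over the (ethoxycarbonyl)methyl chain also survives with this larger group (a 2.3-fold lower number from compound 1 to compound 4 (0.36 log units; beyond the scatter)). Nothing measured here offers an explanation for these numbers. Still open, on these data alone, is whether morpholin-4-yl without the two methyl groups, or piperidin-1-yl, would behave the same way at this carbonyl carbon. A free secondary amine such as piperazin-1-yl also remains to be placed in the series.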